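This account rests on a few compounds, and the source may have more. Where it says the series, first, only, none or still open, it means among the compounds named here.

Measured so far in a functional assay on HT-29 cells (Homo sapiens) for antiproliferative activity, read by MTT assay, with a stated time of 48 h; a lower number here means a stronger inhibitor of growth, a higher number a weaker inhibitor of growth
- compound 1 `COC(=O)N1N=C(c2cccc(OC)c2)CC1c1cc(OC)c(OC)c(OC)c1` gives 1300 nM
- compound 2 `COC(=O)N1N=C(c2ccc(OC)cc2)CC1c1cc(OC)c(OC)c(OC)c1` gives 2550 nM
- compound 3 `COC(=O)N1N=C(c2cccc(O)c2)CC1c1cc(OC)c(OC)c(OC)c1` gives 1350 nM

On these numbers compound 3 cannot be separated from the other two. The gap to compound 2, a 1.9-fold lower number from compound 2 to compound 3 (0.28 log units; within the scatter), lies within the scatter, and so does the gap to compound 1, a 1.0-fold higher number from compound 1 to compound 3 (0.02 log units; within the scatter).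

The next compound is compound 4 `CCOc1cccc(C2=NN(C(=O)OC)C(c3cc(OC)c(OC)c(OC)c3)C2)c1`, which differs from compound 3 by ethyl in place of hydrogen on an oxygen on an aromatic ring. In words, this is ethyl in place of hydrogen on an oxygen on an aromatic ring, taking 3-hydroxyphenyl to 3-ethoxyphenyl.

The closest evidence is the change at that same oxygen between compound 1 and compound 3, where going from methyl to hydrogen gave the step already noted, within the scatter. The change from 3-methoxyphenyl to 4-methoxyphenyl, a 2.0-fold higher number from compound 1 to compound 2 (0.29 log units; within the scatter), also stayed within the scatter. Going by these compounds, no ethyl group has been measured, so this extrapolation remains untested.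

No step beyond the scatter is therefore expected in this assay, and no direction can be assigned with confidence. The estimated step is a 1.1-fold higher number from compound 3 to compound 4 (0.05 log units; within the scatter). The expected value for compound 4 is 1500 nM, with an estimated range of 700 nM to 3200 nM.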

Compound 4, concentration for 50% growth inhibition: 4450 nM
Beside the measured number, compound 4's estimate is 3.0-fold (0.47 log units) below it; measured number above the stated range.
By their numbers in this assay, from the lowest: compounds 1, 3, 2 and 4 (each within the scatter of the next, the first and the last beyond it).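

In this assay, within the data shown here, the oxygen on the aromatic ring is the first site to give a step beyond the scatter: taking 3-hydroxyphenyl to 3-ethoxyphenyl gives a weaker inhibitor of growth (a 3.3-fold higher number from compound 3 to compound 4 (0.52 log units; beyond the scatter)), whereas hydrogen and methyl on this oxygen could not be told apart. Methyl in place of hydrogen on the saturated chain carbon bound to that oxygen points the same way (a 3.4-fold higher number from compound 1 to compound 4 (0.53 log units; beyond the scatter)), so methoxy and ethoxy are separated here even though hydroxy and methoxy are not. The comparison with the 4-methoxyphenyl compound stays unresolved (a 1.7-fold higher number from compound 2 to compound 4 (0.24 log units; within the scatter)), so 3-ethoxyphenyl and 4-methoxyphenyl cannot be ordered. Nothing on hand bears on why ethyl on this oxygen gives this step.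

Open, going by these compounds, is whether a longer chain on this oxygen, such as propyl or butyl, moves the number further or levels off. Also open, on these data alone, is how 3-aminophenyl or 3-carboxyphenyl would compare with 3-hydroxyphenyl, and whether ethyl on the oxygen of 4-methoxyphenyl in place of methyl gives a similar step.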